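Solubility at Low pH for Three Related Compounds

The compounds below may be only part of what the source reports. "The series", "measured", "known", "first", "only" and "open" are said of these compounds alone.

Compound 1 `O=c1nc(N2CCN(CC3CCCCC3)CC2)sc2c([N+](=O)[O-])cc(C(F)(F)F)cc12` and compound 2 `O=c1nc(N2CCC3(CCN(Cc4ccccc4)C3)CC2)sc2c([N+](=O)[O-])cc(C(F)(F)F)cc12` share the same core. In a physicochemical assay for solubility, read by HPLC, with a stated time of 12 h, at pH 2 (a higher number here means a more soluble compound, a lower number a less soluble compound), compound 1 gives 0.9 ug/mL, and compound 2 gives 1.56 ug/mL. Compound 2 carries the highest of the two numbers, yet its gap to compound 1 lies within the scatter, so no order can be read from the pair. Compound 3 `CCOC(=O)CN1CCC2(CCN(c3nc(=O)c4cc(C(F)(F)F)cc([N+](=O)[O-])c4s3)CC2)C1` is still unmeasured. It differs from compound 2 by ethoxycarbonyl in place of phenyl on a saturated chain carbon bound to an amine nitrogen in a ring. Among the measured compounds shown here, no measured step of this kind exists here; a modest rise beyond the scatter is nonetheless expected, a 2.6-fold higher number from compound 2 to compound 3 (0.41 log units; beyond the scatter). Compound 3 is estimated at 4 ug/mL, within 1.5 ug/mL to 12 ug/mL.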

Compound 3, solubility: 2.04 ug/mL
Compound 3: middle estimate off by 2.0-fold (0.29 log units), on the high side, within the range that was stated.
By their numbers in this assay, from the lowest: compounds 1, 2 and 3 (each within the scatter of the next, the first and the last beyond it).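

Among the compounds shown here, the step of a 1.3-fold higher number from compound 2 to compound 3 (0.12 log units; within the scatter) in this assay is the first measured at this position, where ethoxycarbonyl stands in place of phenyl on a saturated chain carbon bound to an amine nitrogen in a ring. It shows that this exchange of an aromatic ring of carbon only for a group with no ring gives no reading beyond the scatter. No measurement shown here gives a cause for this result.

Going by these compounds, whether a carboxylic acid, an amine or a longer chain at this place would give a step beyond the scatter remains open.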